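Series notes: one methoxy removed from compound 2

This account rests on a few compounds, and the source may have more. Where it says the series, first, only, none or still open, it means among the compounds named here.

Measured so far:
compound 1, `COc1cc(-c2cc(/C=C/C(=O)c3ccc(Cl)c(Cl)c3)[nH]n2)cc(OC)c1OC`: 96%
compound 2, `COc1ccc(C(=O)/C=C/c2cc(-c3cc(OC)c(OC)c(OC)c3)n[nH]2)cc1OC`: 100%

Both numbers come from a functional assay on RXF 393 cells (Homo sapiens) for cytotoxicity, read by sulforhodamine B assay, with a stated time of 48 h, tested at 0.1 uM; on this read-out lower numbers stand for a stronger effect and higher numbers for a weaker effect at the one concentration tested. Compound 2 stands highest of the two numbers shown, but only by a number 4 percentage points higher from compound 1 to compound 2 (within the scatter), a step within the scatter, so the two compounds are not distinguished on this read-out; both sit near the top of the scale, where the effect is weak.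

The next compound is compound 3, `COc1ccc(C(=O)/C=C/c2cc(-c3cc(OC)c(OC)c(OC)c3)n[nH]2)cc1`. Its change from compound 2 is hydrogen in place of methoxy on an aromatic carbon, which, read one bond further out, is 3,4-dimethoxyphenyl to 4-methoxyphenyl on the carbonyl carbon. Going by the values given here, no measured step removes a methoxy from this ring. Among the compounds with values here, the only measured step available exchanged both groups on the same carbonyl-bound ring, and it amounted to a number 4 percentage points higher from compound 1 to compound 2 (within the scatter), within the scatter. Within the data shown here, with no precedent for movement in either direction and little room upward, compound 3 is expected to stay within the scatter of compound 2, a step of a number 2 percentage points lower from compound 2 to compound 3 (within the scatter). The estimate for compound 3 is 98%, with a range from 86% to 110%.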

Compound 3, a percentage reported as activity, at one concentration (the size of the read-out at that concentration, not a potency): 90%
Compound 3: the middle estimate sits 8 percentage points above what was measured, and the stated range covers the measured number.
By their numbers in this assay, from the lowest: compounds 3, 1 and 2 (each within the scatter of the next).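

In this assay, hydrogen in place of methoxy on an aromatic carbon, ortho to a methoxy group and meta to a large group, gives a number 10 percentage points lower from compound 2 to compound 3 (within the scatter), so this first look at a single methoxy on the carbonyl-bound ring does not distinguish compound 2 from compound 3. Changing the carbonyl-bound ring gives a number 6 percentage points lower from compound 1 to compound 3 (within the scatter), and with the earlier step this leaves 3,4-dichlorophenyl, 3,4-dimethoxyphenyl and 4-methoxyphenyl unseparated on this read-out, with all three compounds near the weak end of the scale. Nothing at hand offers an explanation for these numbers.

As far as these compounds go, whether a different group on this ring, such as a dimethylamino group or a carboxylic acid in place of the remaining methoxy, would give a step beyond the scatter in this assay stays open. Also open, from the compounds shown here alone, is whether compound 1, compound 2 and compound 3 would separate by a stronger or weaker effect at a higher concentration.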